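This account rests on a few compounds, and the source may have more. Where it says the series, first, only, none or still open, it means among the compounds named here.

Compound 2 `CCC(=O)NCC1CCc2ccccc2N1` gives the lower of the two numbers recorded so far; in an assay on CHO cells for displacement of a labelled ligand from melatonin receptor type 1A (Homo sapiens), with a stated time of 120 min (a higher number here means a weaker inhibitor, a lower number a stronger inhibitor), compound 2 gives 13 nM. The other measured member of the series, compound 1 `CCNC(=O)NCC1CCc2c(cccc2OC)N1`, carries a urea in place of the propanamide and a methoxy on the aromatic ring, and in this assay compound 1 gives 480 nM, a gap that lies beyond the scatter. Compound 1 and compound 2 differ in two places at once, so the two numbers alone do not show how much of that gap belongs to the methoxy and how much to the urea.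

Compound 3 `CCC(=O)NCC1CCc2c(cccc2OC)N1` keeps the propanamide of compound 2 and adds the methoxy of compound 1: methoxy in place of hydrogen on an aromatic carbon. Among the compounds with values here, no measured pair isolates this change, so its direction is open. The working expectation for compound 3 is a step from compound 2 of a 1.1-fold lower number from compound 2 to compound 3 (0.03 log units; within the scatter), not clearly beyond the scatter, with a wide range to cover either direction. On that basis compound 3 is estimated at 12 nM in this assay, between 2 nM and 70 nM.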

Compound 3, inhibition constant: 57 nM
Beside the measured number, compound 3's estimate is 4.8-fold (0.68 log units) below it, and the stated range covers the measured number.
By their numbers in this assay, from the lowest: compound 2; then compound 3; then compound 1.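

In this assay, methoxy in place of hydrogen on an aromatic carbon, ortho to a fused ring and meta to a fused ring, is not neutral in the propanamide series: a 4.4-fold higher number from compound 2 to compound 3 (0.64 log units; beyond the scatter). With the methoxy held constant, ethyl in place of ethylamino on a carbonyl carbon gives an 8.4-fold lower number from compound 1 to compound 3 (0.93 log units; beyond the scatter), so the gap between compound 1 and compound 2 no longer rests on one change alone, as each of its two single changes now has a step beyond the scatter. Each step is read against one background only, the methoxy step with the propanamide present and the ethyl step with the methoxy present, and nothing on hand gives a reason for either step.

The compounds shown leave open whether the methoxy step carries over to the urea, which would take the urea without the methoxy. They also leave open how a hydroxyl group, a fluorine atom or a longer alkoxy chain on the same aromatic carbon would compare with hydrogen and with methoxy in this series.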